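Working notes: changing the group on the sulfonyl sulfur

A few compounds are considered here, and "the series" means these few. Any claim that something is new, unique, unknown or untested is made for them only; others in the source may bear on it.

Measured in a functional assay on HepG2 cells (Homo sapiens) for antiproliferative activity, read by MTT assay, with a stated time of 48 h (a higher number here means that more compound is needed for the effect, a lower number that less compound is needed), as follows:
- compound 1 (`CC1=NN(S(=O)(=O)c2ccc([N+](=O)[O-])cc2)C(c2cc(Br)ccc2O)C1`) gives > 60000 nM as a limit of the assay, not a number
- compound 2 (`CC1=NN(S(=O)(=O)c2ccc(F)cc2)C(c2cc(Br)ccc2O)C1`) gives 50100 nM as a measured number
- compound 3 (`CC1=NN(S(=O)(=O)c2ccc(Cl)cc2Cl)C(c2cc(Br)ccc2O)C1`) gives 45200 nM as a measured number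

Compound 3 (45200 nM) and compound 2 (50100 nM) lie within the scatter of each other, so compound 3 cannot be ranked apart from compound 2. Next comes compound 4 (`COc1ccc(S(=O)(=O)N2N=C(C)CC2c2cc(Br)ccc2O)cc1`). The change is 4-methoxyphenyl in place of 2,4-dichlorophenyl on a sulfonyl sulfur.

Going by the values given here, two measured steps bear on it, both altering the aromatic group on the sulfonyl sulfur. The first is an at least 1.1-fold lower number from compound 1 to compound 2 (0.07 log units; that floor lies within the scatter) and it starts from a limit, so it gives only a floor. The second is a 1.1-fold lower number from compound 2 to compound 3 (0.04 log units; within the scatter) and it is the closer precedent, a swap of the whole group at the same place. Among the compounds with values here, neither step leaves the scatter, and no measured compound carries a methoxy group, so no direction can be read from them. In this assay no step beyond the scatter is therefore expected. The estimated step is a 1.1-fold lower number from compound 3 to compound 4 (0.03 log units; within the scatter) and it is expected to stay small. A reading at the limit of the assay remains possible. For compound 4 the estimated value is 42000 nM with an expected range of 20000 nM to 65000 nM around it.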

Compound 4, half-maximal effective concentration: 38200 nM
Compound 4: middle estimate off by 1.1-fold (0.04 log units), on the high side, and the stated range covers the measured number.
By their numbers in this assay, from the lowest: compounds 4, 3 and 2 (each within the scatter of the next). At a limit, above all of these: compound 1.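

In this assay, a group carrying methoxy on the sulfonyl sulfur gives no step beyond the scatter: a 1.2-fold lower number from compound 3 to compound 4 (0.07 log units; within the scatter), and a 1.3-fold lower number from compound 2 to compound 4 (0.12 log units; within the scatter). The 4-methoxyphenyl group, which counts one hydrogen-bond acceptor where 2,4-dichlorophenyl counts none, therefore joins 2,4-dichlorophenyl and 4-fluorophenyl as a third group that cannot be ranked apart at this place, so compounds 2, 3 and 4 form a single band with no order among them. Compound 1 remains a limit of the assay and not a number, so an at least 1.5-fold lower number from compound 1 to compound 4 (0.19 log units; that floor lies within the scatter) gives only a floor and does not separate the nitro compound from that band: the limit of > 60000 nM in this assay, at which 1 of the 4 values shown sits.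

The compounds shown leave open whether anything other than a substituted phenyl on the sulfonyl sulfur, such as a plain methyl, a longer alkyl chain, or a phenyl bearing an amine or a carboxylic acid, would produce a step beyond the scatter. They also leave open whether a change elsewhere on the shared core would move the numbers, since the group on the sulfonyl sulfur is the only part that varies among them.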